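The compounds below may be only part of what the source reports. "The series", "measured", "known", "first", "only" and "open" are said of these compounds alone.

Measured compounds:

Compound 1 `Cn1c(/C=C2\SC(=O)N(CC(=O)N3CCCCC3)C2=O)nc2ccccc21`; in a functional assay on MDA-MB-231 cells (Homo sapiens) for inhibition, read by MTT assay, with a stated time of 48 h (a higher number here means a weaker inhibitor, a lower number a stronger inhibitor), compound 1 gives > 50000 nM, which is a limit of the assay and not a number.
Compound 2 `CC(C)n1c(/C=C2\SC(=O)N(CC(=O)N3CCCCC3)C2=O)nc2ccccc21`; in this assay compound 2 gives > 50000 nM, again a limit and not a number.
Within the data shown here, compound 3 `COc1cc2c(cc1OC)CN(C(=O)CN1C(=O)S/C(=C\c3nc4ccccc4n3C(C)C)C1=O)CC2`; in this assay compound 3 gives 30600 nM, the only number among the three.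

Compound 2 and compound 1 differ in one place: methyl in place of isopropyl on an aromatic nitrogen. Since both sit at a limit, the step that the two limits leave unreadable from compound 2 to compound 1 cannot be read, as the limit of > 50000 nM in this assay, at which 2 of the 3 values shown sit, makes plain. Compound 3 carries a different core from compound 2, and the difference between the two cores is not broken down here.

Compound 4 `COc1cc2c(cc1OC)CN(C(=O)CN1C(=O)S/C(=C\c3nc4ccccc4n3C)C1=O)CC2` has not been measured yet. It is made from compound 3 by the same change, (methyl in place of isopropyl on an aromatic nitrogen), with the same surroundings. Because the earlier step that the two limits leave unreadable from compound 2 to compound 1 gives no readable size, the step from compound 3 to compound 4 in this assay is expected to be roughly flat, a 1.2-fold higher number from compound 3 to compound 4 (0.09 log units; within the scatter), with wide uncertainty. Compound 4 is therefore estimated at 38000 nM, between 12000 nM and 120000 nM, and a limit rather than a number is a real possibility.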

Compound 4, half-maximal inhibitory concentration: 36000 nM
Beside the measured number, compound 4's estimate is 1.1-fold (0.02 log units) above it; the measured number falls inside the stated range.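

In this assay, putting methyl in place of isopropyl on the aromatic nitrogen gives a 1.2-fold higher number from compound 3 to compound 4 (0.07 log units; within the scatter), so on the core of compound 3 this change makes no difference that can be told apart from ordinary repeat-to-repeat variation. This is a single pair on a single core, so it does not show that the change is neutral in general, and it does not show that the two cores respond alike. Among these compounds, the only other pair with this change offers no comparison, and its step cannot be read because compound 1 and compound 2 both sit at a limit of the assay and not at a number: the limit of > 50000 nM in this assay, at which 2 of the 4 values shown sit.

The compounds shown leave open what a longer chain, such as n-butyl, or a chain ending in an amine or a carboxylic acid would do on that aromatic nitrogen. They also leave open whether any such group would give a number clearly different from that of compound 3 in this assay.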